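The source may report more compounds than this note shows. Statements on the series, on what has been measured and on what is new or still open speak of the compounds shown alone.

Measured so far in a functional assay on brain (Rattus norvegicus, strain Wistar) for inhibition; a lower number here means a stronger inhibitor, a higher number a weaker inhibitor:
- compound 1 `CCCCc1ccc(-c2c(C)[nH]c(=O)n2C2CCCCC2)cc1`: 27100 nM
- compound 2 `CCCCCCCOc1ccc(-c2c(C)[nH]c(=O)n2C2CCCCC2)cc1`: 11600 nM
- compound 3 `CCCCCCCCc1ccc(-c2c(C)[nH]c(=O)n2C2CCCCC2)cc1`: 10300 nM

Compound 3 gives 10300 nM and cannot be separated from compound 2, as a 1.1-fold lower number from compound 2 to compound 3 (0.05 log units; within the scatter) shows. Both sit clearly under compound 1, with a 2.6-fold lower number from compound 1 to compound 3 (0.42 log units; beyond the scatter) and a 2.3-fold lower number from compound 1 to compound 2 (0.37 log units; beyond the scatter).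

The next compound is compound 4 `CCCCCCCCCCCCCCCCCCc1ccc(-c2c(C)[nH]c(=O)n2C2CCCCC2)cc1`. The change is decyl in place of hydrogen on a saturated chain carbon, eight bonds along the chain from an aromatic carbon.

For the measured compounds named here, the closest precedent is the same kind of change made on the shorter chain, butyl in place of hydrogen, with a 2.6-fold lower number from compound 1 to compound 3 (0.42 log units; beyond the scatter). That step was modest, and it is the only measured lengthening of a plain chain. The swap of heptyloxy for octyl, a 1.1-fold lower number from compound 2 to compound 3 (0.05 log units; within the scatter), says little about chain length. Going by the values given here, no measured compound carries a chain longer than that of compound 3, so this is an extrapolation from a single step. The expectation is another modest move towards a lower number, though a result within the scatter of compound 3 would not surprise. The expected step is a 1.7-fold lower number from compound 3 to compound 4 (0.23 log units; within the scatter). For compound 4 the estimated value is 6000 nM, with an expected range of 2000 nM to 20000 nM.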

Compound 4, half-maximal inhibitory concentration: > 100000 nM
Compound 4: no number, only a limit; the forecaster's own chance of this, stated with the estimate: 15%; middle value at least 16-fold (1.22 log units) away from the limit.
By their numbers in this assay, from the lowest: compounds 3 and 2 (each within the scatter of the next); then compound 1. At a limit, above all of these: compound 4.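

Compound 4 gives > 100000 nM in this assay, which is a limit of the assay and not a number, and that limit is the only one in the set: the limit of > 100000 nM in this assay, at which 1 of the 4 values shown sits.

Extension of the plain chain on this saturated carbon does not keep moving in one direction. The earlier lengthening gave a 2.6-fold lower number from compound 1 to compound 3 (0.42 log units; beyond the scatter), whereas adding decyl in place of hydrogen gives an at least 9.7-fold higher number from compound 3 to compound 4 (0.98 log units; beyond the scatter), so the step reverses direction and is larger than the earlier one, which compounds 1, 2 and 3 alone could not show. Any trend of lower numbers with longer chains therefore holds only from compound 1 to compound 3, and compound 4 goes against it.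

On these data alone, the chain length at which the direction turns remains open, since a decyl or dodecyl chain on the aromatic carbon would fall in the gap between compound 3 and compound 4. Also open, as far as these compounds go, is whether a long chain carrying an amine or a carboxylic acid would follow the plain chains or stay in the range of compound 3.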